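Swapping Fluoro for Trifluoromethyl in Compound 4

The source may hold more compounds than are shown below. What is called first, only, known or untested is meant among the compounds shown, and "the series" means these compounds.

Compound 1 `O=C(Nc1cccc(-c2ccccc2C(F)(F)F)c1)C(Cl)Cl` and compound 2 `O=C(Nc1cccc(-c2ccccc2F)c1)C(Cl)Cl` share one core, and in a functional assay on NCI-H460 cells (Homo sapiens) for cytotoxicity, read by MTT assay, with a stated time of 68 h (on this read-out higher numbers stand for weaker inhibition and lower numbers for stronger inhibition), compound 2 gives 26800 nM while compound 1 gives 7550 nM. The change between them is trifluoromethyl in place of fluoro on an aromatic carbon, and it brings a 3.5-fold lower number from compound 2 to compound 1 (0.55 log units; beyond the scatter). Compound 3 `O=C(Nc1cccc(-c2ccc(F)cc2)c1)C(Cl)Cl` has the same atoms as compound 2, joined differently; the difference between the two cores is not broken down here. In this assay compound 3 sits at the limit of > 50000 nM in this assay, at which 1 of the 3 values shown sits, which is a limit and not a number, so its value is given as > 50000 nM. Compound 4 `O=C(Nc1cccc(-c2ccc(C(F)(F)F)cc2)c1)C(Cl)Cl` differs from compound 3 by trifluoromethyl in place of fluoro on an aromatic carbon. Among the compounds with values here, this is the same kind of change as the one from compound 2 to compound 1, though the place differs: "ortho to a large group" there, "para to a large group" here. The step is expected to be an at least 1.2-fold lower number from compound 3 to compound 4 (0.09 log units; that floor lies within the scatter), resting on the measured step of a 3.5-fold lower number from compound 2 to compound 1 (0.55 log units; beyond the scatter). Compound 4 is therefore estimated at 40000 nM.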

Compound 4, half-maximal inhibitory concentration: 33600 nM
Beside the measured number, compound 4's estimate is 1.2-fold (0.08 log units) above it, within the range that was stated.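

In this assay, trifluoromethyl in place of fluoro on the second core gives an at least 1.4-fold lower number from compound 3 to compound 4 (0.17 log units; that floor lies within the scatter). That step starts from a value that is a limit and not a number: the limit of > 50000 nM in this assay, at which 1 of the 4 values shown sits. The values fit a lower number on both cores, but the second step's floor stays within the scatter, so they do not show that the size of the change carries over from one core to the other: the same change on two cores in this assay, a 3.5-fold lower number (0.55 log units; beyond the scatter) from compound 2 to compound 1 and an at least 1.4-fold lower number (0.17 log units; that floor lies within the scatter) from compound 3 to compound 4; the limit leaves it open whether they differ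

The compounds shown leave open how the change would behave on a core where both partners give measured numbers. They also leave open how other groups on the same aromatic carbon, such as a methyl, a nitrile or an amine, would compare with fluoro and trifluoromethyl.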